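The source may report more compounds than this note shows. Statements on the series, on what has been measured and on what is new or still open speak of the compounds shown alone.

Working notes on the series.

Of the compounds shown here, two have been measured so far in an assay on CHO cells for displacement of a labelled ligand from Melanocortin receptor 4 (Homo sapiens); on this read-out higher numbers stand for weaker inhibition and lower numbers for stronger inhibition. Compound 1 `CC[C@H](NC(C)=O)c1cc(Cl)ccc1C1CCN(C(=O)[C@H]2CN(C(C)(C)C)C[C@@H]2c2ccc(F)cc2Cl)CC1` gives 82.2 nM. Compound 2 `CC[C@H](NC(C)=O)c1cc(Cl)ccc1C1CCN(C(=O)[C@@H]2CN(C(C)(C)C)C[C@H]2c2ccc(F)cc2Cl)CC1` is its stereoisomer and gives 216 nM, the highest of the two numbers. The step of a 2.6-fold higher number from compound 1 to compound 2 (0.42 log units; beyond the scatter) is the only one on record, and it rests on (the fact that compounds 1 and 2 differ only in the configuration as drawn), a change of configuration at two ring carbons with no change in atoms or bonds.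

Compound 3 `CC[C@H](NC(C)=O)c1cc(Cl)ccc1C1CCN(C(=O)[C@@H]2CN(C(C)(C)C)C[C@H]2c2ccc(C(F)(F)F)cc2F)CC1` keeps the configuration of compound 2 and alters the aryl group on the five-membered ring: 2-fluoro-4-(trifluoromethyl)phenyl in place of 2-chloro-4-fluorophenyl on a saturated ring carbon. For the measured compounds named here, no measured step in this assay concerns an exchange of aryl substituents; the single step on record, the stereochemical inversion from compound 1 to compound 2, is of a different kind and gives no direction for this change. The expectation for a 1.2-fold higher number from compound 2 to compound 3 (0.06 log units; within the scatter) is therefore a step of small size, in no firm direction, with wide uncertainty. On that basis compound 3 is estimated at 250 nM in this assay, with a range from 80 nM to 800 nM.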

Compound 3, half-maximal inhibitory concentration: 22.7 nM
Compound 3: middle estimate off by 11-fold (1.04 log units), on the high side; measured number below the stated range.
By their numbers in this assay, from the lowest: compound 3; then compound 1; then compound 2.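

In this assay, the aryl group on the saturated ring carbon of the five-membered ring turns out to be a place where the number moves strongly: 2-fluoro-4-(trifluoromethyl)phenyl in place of 2-chloro-4-fluorophenyl gives a 9.5-fold lower number from compound 2 to compound 3 (0.98 log units; beyond the scatter) and this lies beyond the scatter. This step is larger than the only earlier one on record, a 2.6-fold higher number from compound 1 to compound 2 (0.42 log units; beyond the scatter) so in this small set, exchanging the aryl substituents moves the number further than inverting the two ring carbons does. Nothing on record bears on why the aryl exchange lowers the number.

The exchange alters both substituents on the aryl ring at once, so the compounds shown do not separate the two contributions, and a 2-chloro-4-(trifluoromethyl)phenyl group would be needed to tell them apart; whether the same exchange gives a step of like size in the configuration of compound 1 also remains open. The outcome with a nitrile, a methoxy group or a carboxylic acid where the trifluoromethyl stands is likewise unknown from these compounds.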